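Replacing the propargyloxy group: toward compound 4

The compounds below may be only part of what the source reports. "The series", "measured", "known", "first", "only" and "open" are said of these compounds alone.

Measured compounds:
compound 1 `C#CCOc1ccc2c(=O)c(-c3cc(OC)c(OC)cc3OC)coc2c1`: 4500 nM
compound 2 `COc1cc(OC)c(-c2coc3cc(OCc4ccc(F)cc4)ccc3c2=O)cc1OC`: 1120 nM
compound 3 `COc1cc(OC)c(-c2coc3cc(OCc4ccc(C#N)cc4)ccc3c2=O)cc1OC`: 7000 nM

In a functional assay on B16 cells (Mus musculus) for antiproliferative activity, read by MTT assay, with a stated time of 24 h (a lower number here means a stronger inhibitor, a higher number a weaker inhibitor), compound 1 gives 4500 nM, the second highest of the three numbers. Its nearest neighbour is compound 3 (a 1.6-fold higher number from compound 1 to compound 3 (0.19 log units; within the scatter), within the scatter); its furthest is compound 2 (a 4.0-fold lower number from compound 1 to compound 2 (0.60 log units; beyond the scatter)).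

Compound 4 `COc1cc(OC)c(-c2coc3cc(OCc4ccccc4Cl)ccc3c2=O)cc1OC` differs from compound 1 thus: 2-chlorophenyl in place of ethynyl on a saturated chain carbon bound to an oxygen on an aromatic ring.

Within the data shown here, two measured steps bear on this, both putting a substituted phenyl in place of ethynyl at the same position: the 4-fluorophenyl case gave a 4.0-fold lower number from compound 1 to compound 2 (0.60 log units; beyond the scatter), the 4-cyanophenyl case gave a 1.6-fold higher number from compound 1 to compound 3 (0.19 log units; within the scatter), and between those two products the step is a 6.3-fold higher number from compound 2 to compound 3 (0.80 log units; beyond the scatter). A halogenated phenyl thus points to a modestly lower number.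

For compound 4 the expected step is a 2.3-fold lower number from compound 1 to compound 4 (0.35 log units; beyond the scatter). Compound 4 is estimated at 2000 nM, within 700 nM to 6000 nM.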

Compound 4, half-maximal inhibitory concentration: 4180 nM
Beside the measured number, compound 4's estimate is 2.1-fold (0.32 log units) below it, and the stated range covers the measured number.
By their numbers in this assay, from the lowest: compound 2; then compounds 4, 1 and 3 (each within the scatter of the next).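

In this assay, 2-chlorophenyl on the saturated chain carbon leaves the number level with the propargyloxy compound, a 1.1-fold lower number from compound 1 to compound 4 (0.03 log units; within the scatter), and with the 4-cyanophenyl analogue, a 1.7-fold lower number from compound 3 to compound 4 (0.22 log units; within the scatter). A halogen on the phenyl therefore does not by itself give the lower number: compound 2 alone stands apart, a 3.7-fold higher number from compound 2 to compound 4 (0.57 log units; beyond the scatter). No measurement at hand gives a cause for this.

Open: whether 4-chlorophenyl would read with compound 2 or with compound 4, separating the halogen's identity from its place on the phenyl. Going by these compounds, how a carboxylic acid on the phenyl would read also remains open.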